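Series notes: compound 4 expectation

This account rests on a few compounds, and the source may have more. Where it says the series, first, only, none or still open, it means among the compounds named here.

Compound 3 `CCCSc1nc(NC2CC2)c2nc(Nc3ccccc3)sc2n1` carries the highest number of the three measured compounds in a functional assay on NCI-H1650 cells (Homo sapiens) for antiproliferative activity, read by MTT assay, with a stated time of 72 h (on this read-out higher numbers stand for weaker inhibition and lower numbers for stronger inhibition), giving 41700 nM. Compound 1 `CCCSc1nc(Nc2ccccc2)c2nc(Nc3ccccc3)sc2n1` gives 12100 nM and compound 2 `CCCSc1nc(Nc2ccc(OC)cc2)c2nc(Nc3ccccc3)sc2n1` gives 20700 nM. Within the data shown here, the steps that bear on the next change are a 3.4-fold higher number from compound 1 to compound 3 (0.54 log units; beyond the scatter) and a 2.0-fold higher number from compound 2 to compound 3 (0.30 log units; within the scatter); a smaller related step is a 1.7-fold higher number from compound 1 to compound 2 (0.23 log units; within the scatter). Compound 4 `CCCCc1ccc(Nc2nc(SCCC)nc3sc(Nc4ccccc4)nc23)cc1` differs from compound 3 by 4-butylphenyl in place of cyclopropyl on a nitrogen on an aromatic ring. This change runs opposite to the two steps that introduced cyclopropyl, so a lower number is expected, of about the size seen when phenyl was replaced. For compound 4 the expected step is a 2.8-fold lower number from compound 3 to compound 4 (0.44 log units; beyond the scatter). Compound 4 is therefore estimated at 15000 nM, with a range of 6000 nM to 40000 nM.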

Compound 4, half-maximal inhibitory concentration: 14800 nM
Compound 4: middle estimate off by 1.0-fold (0.01 log units), on the high side, and the stated range covers the measured number.
By their numbers in this assay, from the lowest: compounds 1, 4, 2 and 3 (each within the scatter of the next, the first and the last beyond it).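

In this assay, 4-butylphenyl on this nitrogen separates from cyclopropyl, as phenyl does, with a 2.8-fold lower number from compound 3 to compound 4 (0.45 log units; beyond the scatter), although the 4-methoxyphenyl of compound 2 does not separate from cyclopropyl beyond the scatter. Butyl on the aromatic carbon cannot be told apart from hydrogen or methoxy, with a 1.2-fold higher number from compound 1 to compound 4 (0.09 log units; within the scatter) and a 1.4-fold lower number from compound 2 to compound 4 (0.15 log units; within the scatter). This position therefore accepts a four-carbon chain on the aromatic ring without a step beyond the scatter.

From the compounds shown here alone, whether an amine, a carboxylic acid or a longer chain on that ring would give a step beyond the scatter remains open. No evidence is available to explain these steps.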